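Dichlorophenyl Amides and Cytotoxicity in Hamster Kidney Cells

The source may report more compounds than this note shows. Statements on the series, on what has been measured and on what is new or still open speak of the compounds shown alone.

Compound 1 `CC(Sc1nnc(-c2ccncc2)s1)C(=O)Nc1ccccc1` and compound 2 `CC(Sc1nnc(-c2ccncc2)s1)C(=O)Nc1c(Cl)cccc1Cl` share a core and differ in one place: 2,6-dichlorophenyl in place of phenyl on an amide-type nitrogen. In an ADME assay on BHK-21 cells (Mesocricetus auratus) for cytotoxicity, with a stated time of 3 days (on this read-out higher numbers stand for lower toxicity in this test and lower numbers for higher toxicity in this test), compound 1 gives only a limit of the assay, > 50000 nM. Compound 2 likewise reaches only a limit, > 50000 nM. The step that the two limits leave unreadable from compound 1 to compound 2 therefore cannot be sized. Compound 3 `O=C(CCSc1nnc(-c2ccncc2)s1)Nc1ccccc1` has the same atoms as compound 1 joined differently; the difference between the two cores is not broken down here. In this assay compound 3 again gives only a limit, > 50000 nM. Compound 4 `O=C(CCSc1nnc(-c2ccncc2)s1)Nc1c(Cl)cccc1Cl` is not yet measured and differs from compound 3 by the same change, (2,6-dichlorophenyl in place of phenyl on an amide-type nitrogen). Resting on (the limit of > 50000 nM in this assay, at which 3 of the 3 values shown sit), the expected step is a step that the limit leaves unreadable from compound 3 to compound 4, beside the unreadable earlier one. Compound 4 is estimated to give 60000 nM, between 30000 nM and 120000 nM.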

Compound 4, half-maximal cytotoxic concentration: 10300 nM
For compound 4 the middle estimate is 5.8-fold (0.77 log units) above the measured one, outside the stated range (below it).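

In this assay, 2,6-dichlorophenyl in place of phenyl on an amide-type nitrogen brings an at least 4.8-fold lower number from compound 3 to compound 4 (0.68 log units; beyond the scatter) on the core of compound 3, which stands for higher toxicity in this test. The same change on the core of compound 1 cannot be read, since the values on both sides of it are limits of the assay: the limit of > 50000 nM in this assay, at which 3 of the 4 values shown sit. This single readable pair therefore does not show whether the step carries from one core to the other or belongs to the core of compound 3 alone.

The compounds shown leave open whether a fluorophenyl or a methoxyphenyl on the amide-type nitrogen would bring a similar step in this assay. Also open, going by these compounds, is whether a longer chain in the core of compound 3 would go the same way.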